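Notes on the step from compound 3 to compound 4

The source may report more compounds than this note shows. Statements on the series, on what has been measured and on what is new or still open speak of the compounds shown alone.

Three measured compounds share one core and differ in the group on an amine nitrogen in a ring: compound 1 (`Nc1nc(N)c2cc(CSC(=S)N3CCN(C4CCCCC4)CC3)ccc2n1`), compound 2 (`Nc1nc(N)c2cc(CSC(=S)N3CCN(c4ccc(O)cc4)CC3)ccc2n1`) and compound 3 (`Nc1nc(N)c2cc(CSC(=S)N3CCN(c4ccc(Cl)c(Cl)c4)CC3)ccc2n1`). In a functional assay on A549 cells (Homo sapiens) for antiproliferative activity, read by MTT assay, with a stated time of 72 h (on this read-out higher numbers stand for weaker inhibition and lower numbers for stronger inhibition), compound 1 gives 4710 nM, compound 2 gives 4210 nM and compound 3 gives 2940 nM. Compound 3 thus stands within the scatter of both other compounds, and the three cannot be ranked.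

Compound 4 (`Nc1nc(N)c2cc(CSC(=S)N3CCN(c4ccccc4[N+](=O)[O-])CC3)ccc2n1`) has not yet been measured in this assay. It carries 2-nitrophenyl in place of 3,4-dichlorophenyl on an amine nitrogen in a ring.

Among the compounds with values here, the closest precedent is the exchange of one substituted phenyl for another, a 1.4-fold lower number from compound 2 to compound 3 (0.16 log units; within the scatter). The two exchanges away from cyclohexyl are a 1.1-fold lower number from compound 1 to compound 2 (0.05 log units; within the scatter) and a 1.6-fold lower number from compound 1 to compound 3 (0.20 log units; within the scatter). All three steps stay within the scatter, so this small set shows little response to the group at this place. Within the data shown here, no measured compound carries 2-nitrophenyl, so a direct precedent is lacking.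

No change beyond the scatter is expected, and the expected step is a 1.3-fold higher number from compound 3 to compound 4 (0.11 log units; within the scatter). For compound 4 the estimated value is 3800 nM, with an expected range of 1800 nM to 8000 nM.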

Compound 4, half-maximal inhibitory concentration: 4360 nM
Beside the measured number, compound 4's estimate is 1.1-fold (0.06 log units) below it; the range from low to high includes it.
By their numbers in this assay, from the lowest: compounds 3, 2, 4 and 1 (each within the scatter of the next).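

With 2-nitrophenyl on the amine nitrogen in the ring, this assay still shows no step beyond the scatter: a 1.5-fold higher number from compound 3 to compound 4 (0.17 log units; within the scatter), a 1.0-fold higher number from compound 2 to compound 4 (0.02 log units; within the scatter) and a 1.1-fold lower number from compound 1 to compound 4 (0.03 log units; within the scatter). The new group differs from 3,4-dichlorophenyl in its atoms, with nitrogen and oxygen in place of chlorine and 2 hydrogen-bond acceptors where 3,4-dichlorophenyl has 0, yet this exchange leaves the number within the scatter, so the flat response at this position now holds across all four compounds, with the cyclohexyl, 4-hydroxyphenyl, 3,4-dichlorophenyl and 2-nitrophenyl groups. No supporting data bear on why the number responds so little to these exchanges.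

Still open, on these data alone, is whether a group of a different kind at this nitrogen, such as a phenyl ring carrying a carboxylic acid or a primary amine, or a longer alkyl chain in place of the ring, would give a step beyond the scatter. The compounds shown vary only this one place, so the response to changes elsewhere on the shared core also remains open.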